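This account rests on a few compounds, and the source may have more. Where it says the series, first, only, none or still open, it means among the compounds named here.

In a functional assay on HeLa cells (Homo sapiens) for cytotoxicity, read by MTT assay, with a stated time of 24 h (on this read-out higher numbers stand for weaker inhibition and lower numbers for stronger inhibition), compound 3 `COc1cc(/C=C2\CN(C)C/C(=C\c3ccc(F)cc3)C2=O)cc(OC)c1OC` gives 7250 nM, within the scatter of compound 1 `COc1cc(/C=C2\CN(C)C/C(=C\c3ccc(Br)cc3)C2=O)cc(OC)c1` at 5900 nM, while compound 2 `COc1cc(/C=C2\CN(C)C/C(=C\c3cc(OC)c(OC)c(OC)c3)C2=O)cc(OC)c1` gives 2300 nM. Compound 4 `COc1cc(/C=C2\CN(C)C/C(=C\c3ccc(Br)cc3)C2=O)cc(OC)c1OC` differs from compound 3 as follows: bromo in place of fluoro on an aromatic carbon, para to a large group. Going by the values given here, no measured step covers this exchange directly. The only one available, a 3.2-fold higher number from compound 2 to compound 3 (0.50 log units; beyond the scatter), is a modest step that replaces a whole 3,5-dimethoxyphenyl group with 4-fluorophenyl, so it offers only indirect guidance. Compound 1 carries 4-bromophenyl and gives 5900 nM. The expected change is a 1.3-fold lower number from compound 3 to compound 4 (0.10 log units; within the scatter), with no shift beyond the scatter anticipated in this assay. Compound 4 is estimated at 5800 nM, with an expected range of 2300 nM to 14000 nM.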

Compound 4, half-maximal inhibitory concentration: 11900 nM
Beside the measured number, compound 4's estimate is 2.1-fold (0.31 log units) below it, within the range that was stated.
By their numbers in this assay, from the lowest: compound 2; then compounds 1, 3 and 4 (each within the scatter of the next).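

In this assay, bromo in place of fluoro on an aromatic carbon, para to a large group, stays within the scatter (a 1.6-fold higher number from compound 3 to compound 4 (0.22 log units; within the scatter)), and so does methoxy in place of hydrogen on an aromatic carbon (a 2.0-fold higher number from compound 1 to compound 4 (0.30 log units; within the scatter)). Only 4-bromophenyl in place of 3,5-dimethoxyphenyl moves the number beyond the scatter (a 5.2-fold higher number from compound 2 to compound 4 (0.71 log units; beyond the scatter)). No evidence on hand gives a cause for these steps.

Still open, from the compounds shown here alone, is whether an amine or a carboxylic acid on this aromatic carbon would move the number beyond the scatter. Also open, going by these compounds, is whether the step between the two halogens would hold on the core of compound 1.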